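This account rests on a few compounds, and the source may have more. Where it says the series, first, only, none or still open, it means among the compounds named here.

Measured so far in a functional assay on DU-145 cells (Homo sapiens) for inhibition, read by MTT assay, with a stated time of 24 h; a lower number here means a stronger inhibitor, a higher number a weaker inhibitor:
Compound 1 `CCOC(=O)C1=Cc2ccccc2OC1(OCc1cn(-c2ccc(F)cc2)nn1)C(F)(F)F` gives 8900 nM.
Compound 2 `CCOC(=O)C1=Cc2ccccc2OC1(OCc1cn(CC(=O)Nc2cccc(Cl)c2)nn1)C(F)(F)F` gives 10100 nM.
Compound 3 `CCOC(=O)C1=Cc2ccccc2OC1(OCc1cn(CC(=O)Nc2ccc(OC)cc2)nn1)C(F)(F)F` gives 32700 nM.

Compound 3 shows the highest number of the three, its steps to compound 2 and compound 1 both beyond the scatter, so it is the weakest inhibitor here. Compound 4 `CCOC(=O)C1=Cc2ccccc2OC1(OCc1cn(-c2ccccc2)nn1)C(F)(F)F` differs from it by phenyl in place of ((4-methoxyphenyl)carbamoyl)methyl on an aromatic nitrogen. The step that bears on this is a 3.7-fold higher number from compound 1 to compound 3 (0.57 log units; beyond the scatter), since compound 1 carries a closely related ring on the same nitrogen; a 3.2-fold higher number from compound 2 to compound 3 (0.51 log units; beyond the scatter) also points the same way. Reversing that change is expected to lower the number by about a 3.3-fold lower number from compound 3 to compound 4 (0.51 log units; beyond the scatter). Compound 4 is therefore estimated at 10000 nM, range 4000 nM to 25000 nM.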

Compound 4, half-maximal inhibitory concentration: > 150000 nM
Compound 4 ended at the assay's limit; the forecaster's own chance of this, stated with the estimate: 5%; middle value at least 15-fold (1.17 log units) away from the limit.
By their numbers in this assay, from the lowest: compounds 1 and 2 (each within the scatter of the next); then compound 3. At a limit, above all of these: compound 4.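

Compound 4 stands at a limit of this assay, not at a number: the limit of > 150000 nM in this assay, at which 1 of the 4 values shown sits. Hydrogen in place of fluoro on an aromatic carbon is enough to give an at least 16-fold higher number from compound 1 to compound 4 (1.22 log units; beyond the scatter), so on this aromatic nitrogen the 4-fluorophenyl group and the bare phenyl are far from equivalent. The bare phenyl also falls behind both carbamoylmethyl groups, with an at least 14-fold higher number from compound 2 to compound 4 (1.17 log units; beyond the scatter) and an at least 4.5-fold higher number from compound 3 to compound 4 (0.66 log units; beyond the scatter). Still open, as far as these compounds go, is whether this depends on fluoro itself: a chloro, methyl or methoxy group on the same phenyl ring would test that.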